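A few compounds are considered here, and "the series" means these few. Any claim that something is new, unique, unknown or untested is made for them only; others in the source may bear on it.

Measured so far:

Compound 1, `CC(C)(C)N(NC(=O)c1cccc(Cl)c1)C(=O)c1ccccc1Cl`: 155 nM
Compound 2, `CC(C)(C)N(NC(=O)c1ccc(Br)cc1)C(=O)c1ccccc1Cl`: 33.9 nM

Both were tested in an assay on cells for agonist activity at ecdysone receptor (Bombyx mori), read by a luciferase reporter, with a stated time of 24 h; on this read-out higher numbers stand for an effect only at larger amounts of compound and lower numbers for an effect already at smaller amounts. Among the measured compounds shown here, compound 2 holds the lower of the two numbers; the only other measured compound, compound 1, gives a number higher by a 4.6-fold lower number from compound 1 to compound 2 (0.66 log units; beyond the scatter), a change that rests on swapping a 3-chlorophenyl for a 4-bromophenyl on a carbonyl carbon.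

Compound 3, `CCc1ccc(C(=O)NN(C(=O)c2ccccc2Cl)C(C)(C)C)cc1`, has not yet been measured. It differs from compound 2 in one place: ethyl in place of bromo on an aromatic carbon. Neither measured step bears directly on this change. The step from compound 1 to compound 2 swaps one halogen-bearing ring for another, and its size is moderate, but it says nothing about an ethyl group in place of bromo. The two groups are of similar bulk and neither adds a hydrogen-bond donor or acceptor, so the number for compound 3 is expected to stay close to that of compound 2, with a step of a 1.4-fold lower number from compound 2 to compound 3 (0.13 log units; within the scatter) that may well sit within the scatter. The estimate for compound 3 is 25 nM, with a range from 7 nM to 90 nM.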

Compound 3, half-maximal effective concentration: 5.75 nM
For compound 3 the middle estimate is 4.3-fold (0.64 log units) above the measured one; the whole stated range lies above it.
By their numbers in this assay, from the lowest: compound 3; then compound 2; then compound 1.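

In this assay, exchanging bromo for ethyl on the same aromatic carbon, para to a large group, gives a 5.9-fold lower number from compound 2 to compound 3 (0.77 log units; beyond the scatter). This position therefore distinguishes clearly between bromo, with 1 heavy atom, and ethyl, with 2 heavy atoms, even though neither group has a hydrogen-bond donor or acceptor. The wider change from 3-chlorophenyl to 4-ethylphenyl gives a 27-fold lower number from compound 1 to compound 3 (1.43 log units; beyond the scatter) and shows that a halogen on this ring is not required for the lowest number among these three compounds, although no information here explains why ethyl outperforms bromo.

The compounds shown leave open whether a longer chain, such as propyl or butyl, would lower the number further or reverse the gain, and whether the result depends on a carbon chain at all, as a methoxy group or an amine at this position could help to show. They also do not settle whether ethyl would give a similar result on another carbon of the ring, so the finding applies only to this one position and this small set of compounds.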